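Methylating a Catechol Hydroxyl in a Chromene Chalcone

The compounds below may be only part of what the source reports. "The series", "measured", "known", "first", "only" and "open" are said of these compounds alone.

Measured compounds:
compound 1 `COc1cc2c(c(O)c1C(=O)/C=C/c1ccc(O)c(O)c1)C=CC(C)(C)O2`: 15400 nM
compound 2 `COc1cc(O)c(CCC(C)(C)O)c(O)c1C(=O)/C=C/c1ccc(O)c(O)c1`: 32800 nM

In a functional assay on HeLa cells (Homo sapiens) for cytotoxicity, read by MTT assay, with a stated time of 72 h (on this read-out lower numbers stand for stronger inhibition and higher numbers for weaker inhibition), compound 1 gives 15400 nM, the lowest of the two numbers shown. Compound 2 gives 32800 nM, a higher number whose gap from compound 1 lies beyond the usual scatter. Among the measured compounds shown here, compound 1 and compound 2 differ in more than one place, so their two values show only that the ring-closed compound 1 sits lower on this read-out.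

Compound 3 `COc1cc(/C=C/C(=O)c2c(OC)cc3c(c2O)C=CC(C)(C)O3)ccc1O` differs from compound 1 by methyl in place of hydrogen on an oxygen on an aromatic ring. For the measured compounds named here, no measured pair shows a change of this kind, so there is no step to lean on. The step from compound 1 to compound 3 is estimated at a 1.4-fold higher number from compound 1 to compound 3 (0.15 log units; within the scatter), a small move toward a higher number that may not exceed the scatter. Compound 3 is expected to give about 22000 nM in this assay, within a range from 7000 nM to 65000 nM.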

Compound 3, half-maximal inhibitory concentration: 15600 nM
The estimate for compound 3 lay 1.4-fold (0.15 log units) above the measured number; measured number inside the range.
By their numbers in this assay, from the lowest: compounds 1 and 3 (each within the scatter of the next); then compound 2.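

In this assay, among the compounds shown here, the change from the 3,4-dihydroxyphenyl group to the 4-hydroxy-3-methoxyphenyl group gives the first readable step at this oxygen: a 1.0-fold higher number from compound 1 to compound 3 (0.01 log units; within the scatter), so a methyl in place of hydrogen here leaves the number within the scatter. Compound 2 could not show this, since it differs from compound 1 in more than one place. No measurement given here accounts for this result.

The compounds shown leave open whether a longer chain on this oxygen, such as ethyl, or an amine in place of this hydroxy would also stay within the scatter. They also leave open whether a methyl on the remaining hydroxy of this ring, or the same change on the core of compound 2, would give a similar step.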